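A few compounds are considered here, and "the series" means these few. Any claim that something is new, unique, unknown or untested is made for them only; others in the source may bear on it.

Measured so far:
compound 1 `CCc1sc(CCc2cc(OC)cc(NCc3cc(Cl)cc(NC(=O)OC(C)C)c3)n2)nc1C` gives 234 nM in an assay on cells for binding affinity to Neuropeptide Y receptor type 1 (Homo sapiens); on this read-out higher numbers stand for weaker inhibition and lower numbers for stronger inhibition.
compound 2 `CCc1sc(CCc2cc(OC3CCC3)cc(NCc3cc(Cl)cc(NC(=O)OC(C)C)c3)n2)nc1C` gives 11 nM in this assay.
compound 3 `CCc1sc(CCc2cc(OC3CCCCC3)cc(NCc3cc(Cl)cc(NC(=O)OC(C)C)c3)n2)nc1C` gives 29 nM in this assay.

Compound 3 holds the second highest of the three numbers. Its nearest neighbour on the scale is reached by a 2.6-fold higher number from compound 2 to compound 3 (0.42 log units; beyond the scatter), the furthest by an 8.1-fold lower number from compound 1 to compound 3 (0.91 log units; beyond the scatter).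

Compound 4 `CCc1sc(CCc2cc(OCc3ccccc3)cc(NCc3cc(Cl)cc(NC(=O)OC(C)C)c3)n2)nc1C` is not yet measured. The change from compound 3 is benzyl in place of cyclohexyl on an oxygen on an aromatic ring. All three measured steps sit on the same oxygen on an aromatic ring and therefore bear on it. a 21-fold lower number from compound 1 to compound 2 (1.33 log units; beyond the scatter) and an 8.1-fold lower number from compound 1 to compound 3 (0.91 log units; beyond the scatter) show that a ring in place of methyl lowers the number strongly, while a 2.6-fold higher number from compound 2 to compound 3 (0.42 log units; beyond the scatter) shows that going from the four-membered to the six-membered ring raises it modestly. No measured step exchanges a non-aromatic ring for an aromatic one at this position, so the direction of this particular change is not anchored by any pair shown. Compound 4 is therefore expected to give about 25 nM, with an estimated range from 8 nM to 80 nM. The expected step is a 1.2-fold lower number from compound 3 to compound 4 (0.06 log units; within the scatter), which is within the scatter.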

Compound 4, half-maximal inhibitory concentration: 237 nM
The estimate for compound 4 lay 9.5-fold (0.98 log units) below the measured number; measured number outside the range, above it.
By their numbers in this assay, from the lowest: compound 2; then compound 3; then compounds 1 and 4 (each within the scatter of the next).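

Benzyl on this oxygen does not keep the lower numbers seen with the saturated rings, in either comparison (an 8.2-fold higher number from compound 3 to compound 4 (0.91 log units; beyond the scatter)) (a 22-fold higher number from compound 2 to compound 4 (1.33 log units; beyond the scatter)). Read as phenyl in place of hydrogen on a saturated chain carbon bound to an oxygen on an aromatic ring, the change leaves no separation from the methyl ether (a 1.0-fold higher number from compound 1 to compound 4 (0.01 log units; within the scatter)). Group size alone therefore does not order this position: compounds 2 and 3 fit the idea that a group larger than methyl lowers the number, but compound 4 goes against it.

No measured property bears on this result. On these data alone, whether the aromatic ring or the methylene link goes with the higher number stays open; phenyl directly on the oxygen and cyclohexylmethyl are the groups that would separate the two.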